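The compounds below may be only part of what the source reports. "The series", "measured", "known", "first", "only" and "open" are said of these compounds alone.

Measured so far:
- compound 1, `O=C1/C(=C/c2ccccc2)CCC/C1=C\c1ccc(F)cc1`: 34%
- compound 2, `O=C(/C=C(O)/C=C/c1cc(O)ccc1O)c1ccc(O)cc1O`: 86.6%
- compound 3, `O=C(/C=C(O)/C=C/c1ccc(O)c(O)c1)c1cc(Cl)ccc1O`: 85.6%

In an assay on isolated protein for inhibition of Alpha glucosidase (Homo sapiens), with stated times of 5 min and 15 min, tested at 50 uM (on this read-out higher numbers stand for more inhibition at the one concentration tested (going by the name of the read-out) and lower numbers for less inhibition), compound 1 gives 34% and stands lowest of the three numbers. The nearest number is that of compound 3, 85.6%, and the furthest that of compound 2, 86.6%; both sit beyond the scatter above compound 1. Going by the values given here, neither of those two compounds shares the core of compound 1, so no step between measured compounds exists that bears on the change now in question.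

Compound 4, `O=C1/C(=C/c2ccccc2)CCC/C1=C\c1cccc(F)c1`, differs from compound 1 in one place: 3-fluorophenyl in place of 4-fluorophenyl on a double-bonded chain carbon bound to a double-bonded ring carbon. The change moves a single fluorine on the same ring and leaves everything else in the molecule as it is. Among the compounds with values here, with no measured step of this kind to lean on, the expectation in this assay is a step of no size beyond the scatter, in either direction. For compound 4 the estimated value is therefore 34%, with a range from 18% to 52%. This estimate means an expected step of no change at the digits printed from compound 1 to compound 4 (within the scatter).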

Compound 4, a percentage reported as inhibition, at one concentration (the size of the read-out at that concentration, not a potency): 39.8%
Beside the measured number, compound 4's estimate is 5.8 percentage points below it; the range from low to high includes it.
By their numbers in this assay, from the lowest: compounds 1 and 4 (each within the scatter of the next); then compounds 3 and 2 (each within the scatter of the next).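

In this assay, going by these compounds alone, 3-fluorophenyl in place of 4-fluorophenyl on a double-bonded chain carbon bound to a double-bonded ring carbon gives a number 5.8 percentage points higher from compound 1 to compound 4 (within the scatter), the first step that can be read within the shared core of compound 1. At this place, the read-out at the one concentration tested therefore does not separate these two fluorophenyl groups beyond the scatter. No measurement at hand bears on the reason for this result.

This step covers only a shift of one fluorine on the same ring, so it leaves open whether a different group on that ring, such as an amine or a carboxylic acid, would move the number beyond the scatter. Also open, from the compounds shown here alone, is how either compound would rank by potency, since a single-concentration percentage does not give one.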